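The source may report more compounds than this note shows. Statements on the series, on what has been measured and on what is new or still open speak of the compounds shown alone.

Working notes on the series. Three analogues sharing one core have been measured in a functional assay on aorta (Rattus norvegicus, strain Wister); a higher number here means a weaker inhibitor, a lower number a stronger inhibitor. Compound 1 `COc1nc(-c2nc3ccccc3[nH]2)cc(-c2ccc(Cl)cc2)c1C#N` gives 286000 nM. Compound 2 `CCOc1nc(-c2nc3ccccc3n2C)cc(-c2ccc(Cl)cc2)c1C#N` gives 293000 nM. Compound 3 `COc1ccc(-c2cc(-c3nc4ccccc4n3C)nc(OC)c2C#N)cc1` gives 210000 nM. On the numbers as written compound 2 carries the highest figure, yet its gap to compound 1 and its gap to compound 3 both lie within the scatter, so the three read-outs cannot be told apart. No pair among these compounds differs in a single place, so no step in this assay has yet been tied to one structural change.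

Compound 4 `CCOc1nc(-c2nc3ccccc3n2C)cc(-c2ccc(C)o2)c1C#N` has not been measured. It differs from compound 2 as follows: 5-methylfuran-2-yl in place of 4-chlorophenyl on an aromatic carbon. Nothing measured in this series speaks to a 5-methylfuran-2-yl group on that aromatic carbon, so no step beyond the scatter is expected; the expected step is a 1.0-fold higher number from compound 2 to compound 4 (0.01 log units; within the scatter), inside the ordinary spread. In this assay compound 4 is therefore estimated at about 300000 nM, with a likely range from 120000 nM to 800000 nM.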

Compound 4, half-maximal inhibitory concentration: 336000 nM
Compound 4: middle estimate off by 1.1-fold (0.05 log units), on the low side; the measured number falls inside the stated range.
By their numbers in this assay, from the lowest: compounds 3, 1, 2 and 4 (each within the scatter of the next).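

Going by these compounds alone, the swap of 4-chlorophenyl for 5-methylfuran-2-yl gives a 1.1-fold higher number from compound 2 to compound 4 (0.06 log units; within the scatter) in this assay and is the first change tied to one place. On this aromatic carbon, ortho to a cyano group, a six-membered aromatic ring of carbon only and a five-membered aromatic ring with 1 hetero atom cannot be told apart, even though the chlorine leaves and a hydrogen-bond acceptor enters. Nothing available explains this result.

On these data alone, whether an amine or a carboxylic acid on this carbon would move the number beyond the scatter remains open. As far as these compounds go, the ethoxy group and the methyl on the benzimidazole-side nitrogen also remain untested as single changes, since only this one position has a single-place comparison.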